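Swapping the Benzyl Halogen Pattern on a Spiro Indole Core

A few compounds are considered here, and "the series" means these few. Any claim that something is new, unique, unknown or untested is made for them only; others in the source may bear on it.

Measured compounds:
compound 1, `COc1ccc2[nH]c3c(c2c1)CCNC31CCN(Cc2ccc(Br)cc2F)CC1`, 1600 nM
compound 2, `COc1ccc2[nH]c3c(c2c1)CCNC31CCN(Cc2c(F)c(F)c(F)c(F)c2F)CC1`, 2100 nM

Both compounds were tested in an assay on FRT cells for positive allosteric modulation of Cystic fibrosis transmembrane conductance regulator variant N1303K (Homo sapiens), in the presence of a further agent that is not named here; a higher number here means that more compound is needed for the effect, a lower number that less compound is needed. In this assay compound 1 gives 1600 nM, while compound 2 gives 2100 nM. The two numbers lie within the usual scatter of each other, so the measurements do not separate compound 1 from compound 2; the two compounds share the same core and differ only in the halogen pattern on the benzyl group attached to the ring amine.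

Compound 3, `COc1ccc2[nH]c3c(c2c1)CCNC31CCN(Cc2ccc(F)c(F)c2F)CC1`, has not yet been measured in this assay. It carries 2,3,4-trifluorophenyl in place of 4-bromo-2-fluorophenyl on a saturated chain carbon bound to an amine nitrogen in a ring. The change thus moves from a bromine-containing pattern to one made of fluorine only, in a pattern that sits between those of compound 1 and compound 2 in terms of its count of fluorine atoms. Since the change from compound 1 to compound 2 produced no step beyond the scatter, a small step, if any, is expected from compound 1 to compound 3, estimated as a 1.2-fold higher number from compound 1 to compound 3 (0.07 log units; within the scatter). Compound 3 is therefore expected to give about 1900 nM, with a likely range from 900 nM to 4000 nM.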

Compound 3, half-maximal effective concentration: 4100 nM
Compound 3: the middle estimate sits 2.2-fold (0.33 log units) below what was measured; the whole stated range lies below it.
By their numbers in this assay, from the lowest: compounds 1, 2 and 3 (each within the scatter of the next, the first and the last beyond it).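

In this assay, the halogen pattern on the benzyl group attached to the ring amine can move the number beyond the usual scatter: the change gives a 2.6-fold higher number from compound 1 to compound 3 (0.41 log units; beyond the scatter), a modest step, and the first here that the measurements can separate. Fluorine count alone does not order these results, as compound 2 carries more fluorine than compound 3 yet lies within the scatter of both compound 1 and compound 3, so the arrangement or identity of the halogens may matter, though three compounds cannot settle this. No measurement shown here gives a reason for the step.

The compounds shown do not separate the loss of the bromine from the gain of the added fluorines, so it remains open which part of the change accounts for the step. Also open, from the compounds shown here alone, is how an unsubstituted phenyl ring, a chlorine in place of the bromine, or a ring carrying a nitrile or a methoxy group would read in this assay on the same shared core.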